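Trading One Hydroxamate Arm for a Dimethylamide

The source may report more compounds than this note shows. Statements on the series, on what has been measured and on what is new or still open speak of the compounds shown alone.

Measured so far:
compound 1, `CC(C)[C@H](C(=O)O)N(CCNC(=O)c1cccc(C(=O)NCCN([C@@H](C(=O)O)C(C)C)S(=O)(=O)c2ccc(-c3ccccc3)cc2)c1)S(=O)(=O)c1ccc(-c2ccccc2)cc1`: 26 nM
compound 2, `CC(C)[C@H](C(=O)NO)N(CCNC(=O)c1cccc(C(=O)NCCN([C@@H](C(=O)NO)C(C)C)S(=O)(=O)c2ccc(-c3ccccc3)cc2)c1)S(=O)(=O)c1ccc(-c2ccccc2)cc1`: 5.5 nM

Both were tested in an assay on CHO cells for inhibition of matrix metalloproteinase-9 (Homo sapiens), read by fluorescence, with stated times of 4 h, 15 s and 20 min; a higher number here means a weaker inhibitor, a lower number a stronger inhibitor. Compound 2 has the lower of the two numbers; the gap up to compound 1 lies beyond the usual scatter, so compound 2 is the stronger inhibitor of this pair.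

Compound 3, `CC(C)[C@H](C(=O)NO)N(CCNC(=O)c1cccc(C(=O)NCCN([C@@H](C(=O)N(C)C)C(C)C)S(=O)(=O)c2ccc(-c3ccccc3)cc2)c1)S(=O)(=O)c1ccc(-c2ccccc2)cc1`, keeps the shared core but differs from compound 2 at one end: dimethylamino in place of hydroxyamino on a carbonyl carbon. Within the data shown here, no pair of measured compounds differs in a single place, so no measured step can be consulted directly. Because compound 1 gives 26 nM whereas compound 2 gives 5.5 nM, the hydroxyamino ends appear to matter, and removing one of them is expected to weaken inhibition. The step from compound 2 to compound 3 is therefore estimated at a 9.1-fold higher number from compound 2 to compound 3 (0.96 log units; beyond the scatter), beyond the scatter. Compound 3 is expected to give about 50 nM, within a range from 12 nM to 250 nM.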

Compound 3, half-maximal inhibitory concentration: 41 nM
Estimate against measurement, compound 3: 1.2-fold (0.09 log units) above; low and high end bracket the measured number.
By their numbers in this assay, from the lowest: compound 2; then compounds 1 and 3 (each within the scatter of the next).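

Among these compounds, compound 2 and compound 3 differ in one place only, so this is the first direct reading of this position in this assay: dimethylamino in place of hydroxyamino on a carbonyl carbon gives a 7.5-fold higher number from compound 2 to compound 3 (0.87 log units; beyond the scatter) and so weakens inhibition. The loss appears even though compound 3 keeps its other hydroxyamino end, so that remaining end alone does not preserve the inhibition seen with compound 2. No measurement shown gives a reason for this step.

Going by these compounds, it remains open whether a smaller replacement on the same carbonyl carbon, such as methylamino or a plain amino group, would weaken inhibition as much as dimethylamino does. On these data alone, it is also open whether the same change at the other end of the molecule would give a step of similar size.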